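Urea-linked pyrimidines on HCC827 cells: a swap at the amine

The source may report more compounds than this note shows. Statements on the series, on what has been measured and on what is new or still open speak of the compounds shown alone.

Measured so far:
Compound 1, `COc1ccc(Nc2cc(NC(=O)Nc3c(Cl)cccc3Cl)ncn2)cc1C`, gives 63.1% in a functional assay on HCC827 cells (Homo sapiens) for inhibition, read by MTT assay, with a stated time of 48 h, tested at 10 uM; on this read-out higher numbers stand for more inhibition at the one concentration tested (going by the name of the read-out) and lower numbers for less inhibition.
Compound 2, `COc1cc(NC(=O)Nc2cc(Nc3cc(I)ccc3OC)ncn2)cc(OC)c1`, gives 71%.

Compound 2 has the highest of the two numbers, yet its nearest neighbour is compound 1, whose value lies within the scatter of it. Compound 3, `COc1cc(NC(=O)Nc2cc(Nc3ccc(OC)c(C)c3)ncn2)cc(OC)c1`, differs from compound 2 by 4-methoxy-3-methylphenyl in place of 5-iodo-2-methoxyphenyl on a nitrogen on an aromatic ring. Among the compounds with values here, no step between measured compounds bears on this change, so no direction beyond the scatter is expected, and the step of a number 5 percentage points lower from compound 2 to compound 3 (within the scatter) is estimated as small. Compound 3 is expected to give 66%, between 50% and 80%.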

Compound 3, a percentage reported as inhibition, at one concentration (the size of the read-out at that concentration, not a potency): 48.3%
Estimate against measurement, compound 3: 17.7 percentage points above; measured number below the stated range.
By their numbers in this assay, from the lowest: compound 3; then compounds 1 and 2 (each within the scatter of the next).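

With 3,5-dimethoxyphenyl held on the amide-type nitrogen, 4-methoxy-3-methylphenyl in place of 5-iodo-2-methoxyphenyl on a nitrogen on an aromatic ring gives a number 22.7 percentage points lower from compound 2 to compound 3 (beyond the scatter) and so shows that this position matters. With 4-methoxy-3-methylphenyl held, 3,5-dimethoxyphenyl in place of 2,6-dichlorophenyl on the amide-type nitrogen gives a number 14.8 percentage points lower from compound 1 to compound 3 (beyond the scatter) so the other end of the molecule counts as well. Nothing available here accounts for either step.

Which part of the first change carries its step stays open, whether the iodine, the methyl or the placing of the methoxy. So does the outcome with a pyridine ring in place of either phenyl group.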